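A few compounds are considered here, and "the series" means these few. Any claim that something is new, unique, unknown or untested is made for them only; others in the source may bear on it.

Measured so far in a functional assay on OVCAR-4 cells (Homo sapiens) for cytotoxicity, read by sulforhodamine B assay, with a stated time of 48 h, tested at 1 uM; a lower number here means a stronger effect, a higher number a weaker effect of the compound at the concentration tested:
compound 1 `COc1cc(-c2cc(/C=C/C(=O)c3ccc(N)cc3)[nH]n2)cc(OC)c1OC`: 62%
compound 2 `COc1cc(-c2cc(/C=C/C(=O)c3ccc(Cl)c(Cl)c3)[nH]n2)cc(OC)c1OC`: 107%

Compound 2 gives the highest of the two numbers; the one step shown, a number 45 percentage points higher from compound 1 to compound 2 (beyond the scatter), is large. Compound 3 `COc1ccc(C(=O)/C=C/c2cc(-c3cc(OC)c(OC)c(OC)c3)n[nH]2)cc1OC` differs from compound 2 by 3,4-dimethoxyphenyl in place of 3,4-dichlorophenyl on a carbonyl carbon. Going by the values given here, no measured step exchanges one substituted phenyl for another on this carbonyl carbon, so the step in this assay is uncertain; the weak number of compound 2 leaves room mainly downward. A modest shift is expected, a number 22 percentage points lower from compound 2 to compound 3 (beyond the scatter). Compound 3 is estimated at 85%, within 55% to 110%.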

Compound 3, a percentage reported as activity, at one concentration (the size of the read-out at that concentration, not a potency): 70%
Beside the measured number, compound 3's estimate is 15 percentage points above it, and the stated range covers the measured number.
By their numbers in this assay, from the lowest: compounds 1 and 3 (each within the scatter of the next); then compound 2.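

On the carbonyl carbon, the exchange of one substituted phenyl for another is not neutral: this assay shows a number 37 percentage points lower from compound 2 to compound 3 (beyond the scatter) for the change from 3,4-dichlorophenyl to 3,4-dimethoxyphenyl. The stronger number is also not confined to 4-aminophenyl, as the 3,4-dimethoxyphenyl group gives a number 8 percentage points higher from compound 1 to compound 3 (within the scatter) and so matches it. Nothing available explains this difference between the groups.

Open, on these data alone, is whether both methoxy groups are needed at this position. A single methoxy group, a hydroxyl group or a carboxylic acid on this phenyl would help to settle that.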